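Chain extension in a small cell-inhibition series

The source may report more compounds than this note shows. Statements on the series, on what has been measured and on what is new or still open speak of the compounds shown alone.

Measured so far:
compound 1 `CC(C)=CCC1Cc2c(OCc3ccccc3)cc(=O)n(CCCO)c2CC1(C)C` gives 11.1% in a functional assay on PANC-1 cells (Homo sapiens) for inhibition, read by MTT assay, with a stated time of 24 h, tested at 10 uM; on this read-out higher numbers stand for more inhibition at the one concentration tested (going by the name of the read-out) and lower numbers for less inhibition.
compound 3 `CC(C)=CCC/C(C)=C/CC1Cc2c(OCc3ccccc3)cc(=O)n(CCCO)c2CC1(C)C` gives 1.5% in this assay.
compound 2 `CC(C)=CCC1Cc2c(OCCCNS(=O)(=O)c3ccc(C(F)(F)F)cc3)cc(=O)n(CCCO)c2CC1(C)C` gives 0% in this assay.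

Compound 2 differs from compound 1 in more than one place; the difference between the two cores is not broken down here. Compound 3 arises from compound 1 by 3-methylbut-2-en-1-yl in place of hydrogen on a saturated chain carbon bound to a double-bonded chain carbon, and this change gave a number 9.6 percentage points lower from compound 1 to compound 3 (within the scatter). Compound 2 has the lowest number of the three, within the scatter of compound 3 and beyond it only against compound 1.

Compound 4 `CC(C)=CCC/C(C)=C/CC1Cc2c(OCCCNS(=O)(=O)c3ccc(C(F)(F)F)cc3)cc(=O)n(CCCO)c2CC1(C)C` carries the same change on the core of compound 2: 3-methylbut-2-en-1-yl in place of hydrogen on a saturated chain carbon bound to a double-bonded chain carbon. The place is the same word for word, so it is the same change. Because compound 2 already gives 0% and the earlier step was within the scatter, the step of a number 1 percentage points higher from compound 2 to compound 4 (within the scatter) is expected to be small. Compound 4 is estimated at 1%, within 0% to 9%.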

Compound 4, a percentage reported as inhibition, at one concentration (the size of the read-out at that concentration, not a potency): 0%
Estimate against measurement, compound 4: 1 percentage points above; measured number inside the range.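

On the core of compound 2, 3-methylbut-2-en-1-yl in place of hydrogen on a saturated chain carbon bound to a double-bonded chain carbon gives no change at the digits printed from compound 2 to compound 4 (within the scatter). Set beside the earlier step, the two cores cannot be told apart in this assay: the same change on two cores in this assay, a number 9.6 percentage points lower (within the scatter) from compound 1 to compound 3 and no change at the digits printed (within the scatter) from compound 2 to compound 4, 9.6 percentage points apart, within the scatter of two such steps. This does not show that the change carries over with equal effect, since all of these steps lie within the scatter and, with compound 2 at 0%, a downward step on that core could hardly be seen.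

The compounds shown leave open whether a chain ending in an amine or a carboxylic acid, in place of 3,7-dimethylocta-2,6-dien-1-yl, would move the number in this assay.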